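The compounds below may be only part of what the source reports. "The series", "measured", "known", "first", "only" and "open" are said of these compounds alone.

Measured compounds:
compound 1 `N#Cc1cnc(NCc2cnccc2C(F)(F)F)cc1N[C@H]1C[C@H](O)C1`: 900 nM
compound 2 `CC1(C)C[C@H](Nc2cc(NCc3cnccc3C(F)(F)F)ncc2C#N)CC[C@@H]1O`: 7 nM

For the measured compounds named here, in an assay on isolated protein for inhibition of protein kinase C theta type (Homo sapiens), read by TR-FRET, with a stated time of 2 h (a higher number here means a weaker inhibitor, a lower number a stronger inhibitor), compound 2 gives the lower of the two numbers; the one step known is a 130-fold lower number from compound 1 to compound 2 (2.11 log units; beyond the scatter). Compound 3 `CC1(C)[C@@H](Nc2cc(NCc3cnccc3C(F)(F)F)ncc2C#N)C[C@H]1C(N)=O` carries the change (3-carbamoyl-2,2-dimethylcyclobutyl in place of 4-hydroxy-3,3-dimethylcyclohexyl on a nitrogen on an aromatic ring), at the same nitrogen the earlier step altered. That step, a large one, shows how much the ring on this nitrogen matters, and compound 3 returns to a four-membered ring, as in compound 1, though with other substituents. Compound 3 is therefore expected to give a higher number, a 17-fold higher number from compound 2 to compound 3 (1.23 log units; beyond the scatter), with an estimate of 120 nM and a range from 20 nM to 700 nM.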

Compound 3, half-maximal inhibitory concentration: 140 nM
Beside the measured number, compound 3's estimate is 1.2-fold (0.07 log units) below it; low and high end bracket the measured number.
By their numbers in this assay, from the lowest: compound 2; then compound 3; then compound 1.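

With the four-membered ring kept on the nitrogen, 3-carbamoyl-2,2-dimethylcyclobutyl still gives a 6.4-fold lower number from compound 1 to compound 3 (0.81 log units; beyond the scatter) in this assay, so ring size alone does not set the number at this position. Yet replacing 4-hydroxy-3,3-dimethylcyclohexyl gives a 20-fold higher number from compound 2 to compound 3 (1.30 log units; beyond the scatter), so the four-membered ring recovers only part of the gain seen with the six-membered ring.

From the compounds shown here alone, whether that recovery comes from the two methyl groups or from the carbamoyl group stays open, as does how a carboxylic acid or a plain hydroxy group on the dimethylcyclobutyl ring would compare. No evidence at hand explains these steps.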